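Selenium side chains: from compound 2 to compound 3

A few compounds are considered here, and "the series" means these few. Any claim that something is new, unique, unknown or untested is made for them only; others in the source may bear on it.

Measured in a functional assay on LoVo cells (Homo sapiens) for inhibition, read by MTT assay, with a stated time of 48 h (a higher number here means a weaker inhibitor, a lower number a stronger inhibitor), so far:
compound 1 `COc1ccc(N(C)c2nc(C)nc3ccccc23)cc1OCCCCCC[Se]C#N` gives 8580 nM
compound 2 `COc1ccc(N(C)c2nc(C)nc3ccccc23)cc1[Se]C` gives 3 nM

Compound 2 (3 nM) holds the lower of the two numbers, so any change from it can be tested against a strong starting point. Compound 3 (`COc1ccc(N(C)c2nc(C)nc3ccccc23)cc1C(=O)OCCCC[Se]C#N`) is still unmeasured in this assay and differs from compound 2 by a group of 10 heavy atoms (6 carbon, 1 nitrogen, 2 oxygen, 1 selenium; no ring) in place of a group of 2 heavy atoms (1 carbon, 1 selenium; no ring), on an aromatic carbon in the same place. Among the compounds with values here, only one measured step bears on this: a 2900-fold lower number from compound 1 to compound 2 (3.46 log units; beyond the scatter) ( large, beyond the scatter ), where a group of 10 heavy atoms gave way to a group of 2 heavy atoms. The change to compound 3 runs the opposite way, so a large rise is expected, given as a 670-fold higher number from compound 2 to compound 3 (2.82 log units; beyond the scatter) in the estimate. One step is thin support and the two long groups are not identical, so the range is wide. For compound 3 the expected value is 2000 nM ( estimated range 200 nM to 12000 nM).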

Compound 3, half-maximal inhibitory concentration: 1080 nM
Compound 3: middle estimate off by 1.9-fold (0.27 log units), on the high side; measured number inside the range.
By their numbers in this assay, from the lowest: compound 2; then compound 3; then compound 1.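

In this assay, the second long selenium-bearing group on this aromatic carbon also gives a large change, a 360-fold higher number from compound 2 to compound 3 (2.56 log units; beyond the scatter), so the loss seen with compound 1 is not confined to a single long group. The two long groups each have 10 heavy atoms yet still separate, a 7.9-fold lower number from compound 1 to compound 3 (0.90 log units; beyond the scatter), so heavy-atom count alone does not set the number at this position, and the make-up of the group matters. No measurement shown here bears on the reason for either step.

As far as these compounds go, it remains open whether a short carboxylic acid or a small amine on this carbon would stay close to compound 2 at 3 nM. Also open, from the compounds shown here alone, is how a long carbon chain without selenium or the nitrile end would compare with compound 3.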